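The compounds below may be only part of what the source reports. "The series", "measured", "known", "first", "only" and "open" are said of these compounds alone.

Measured compounds:
Compound 1 `Cc1ccc(-c2ccc(C(=O)N=C(N)N)cc2S(C)(=O)=O)cc1` gives 100 nM in a functional assay for inhibition of sodium/hydrogen exchanger (Oryctolagus cuniculus); a higher number here means a weaker inhibitor, a lower number a stronger inhibitor.
Compound 2 `Cc1ccc(C(=O)N=C(N)N)cc1S(C)(=O)=O` gives 210 nM in this assay.

Within the data shown here, compound 2 stands at the higher of the two numbers measured so far; its nearest neighbour is compound 1, and the step of a 2.1-fold higher number from compound 1 to compound 2 (0.32 log units; beyond the scatter) lies beyond the scatter and counts as modest, a methyl taking the place of 4-methylphenyl on an aromatic carbon. Compound 3 `CS(=O)(=O)c1cc(C(=O)N=C(N)N)ccc1-n1ccc(=O)cc1` is the next compound to be measured. It differs from compound 2 in one place: a group of 7 heavy atoms (5 carbon, 1 nitrogen, 1 oxygen; one six-membered aromatic ring with 1 hetero atom) in place of one carbon atom, on an aromatic carbon. Among the measured compounds shown here, only one measured step bears on this change. In the step from compound 1 to compound 2 a methyl in place of a larger aromatic group raised the number modestly; the move to compound 3 reverses the direction, putting a ring-bearing group back in place of the methyl. A modest lowering is therefore expected. Compound 3 is estimated at 80 nM in this assay, within 35 nM to 200 nM, because a 2.1-fold higher number from compound 1 to compound 2 (0.32 log units; beyond the scatter) went the opposite way for the opposite kind of change; the expected step is a 2.6-fold lower number from compound 2 to compound 3 (0.42 log units; beyond the scatter).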

Compound 3, half-maximal inhibitory concentration: 710 nM
Beside the measured number, compound 3's estimate is 8.9-fold (0.95 log units) below it, outside the stated range (above it).
By their numbers in this assay, from the lowest: compound 1; then compound 2; then compound 3.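

At this aromatic carbon, ortho to a methylsulfonyl group, replacing the methyl with a ring-bearing group does not of itself give a stronger inhibitor in this assay: the change brings a 3.4-fold higher number from compound 2 to compound 3 (0.53 log units; beyond the scatter) and so runs the opposite way to what the 4-methylphenyl group of compound 1 showed. Compound 1 and compound 3 both carry a group of 7 heavy atoms here, yet exchanging the ring of carbon only for the ring with 1 hetero atom gives a 7.1-fold higher number from compound 1 to compound 3 (0.85 log units; beyond the scatter), the widest step among the three compounds. Heavy-atom count alone therefore does not set the number at this position; across these compounds, the make-up of the ring matters too.

From the compounds shown here alone, it remains open whether the rise follows the ring nitrogen or the carbonyl, and where an unsubstituted phenyl or a morpholine would fall. Nothing measured here explains the difference between the two rings.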